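This account rests on a few compounds, and the source may have more. Where it says the series, first, only, none or still open, it means among the compounds named here.

In a functional assay on MGC-803 cells (Homo sapiens) for inhibition, read by MTT assay, with a stated time of 72 h (a higher number here means a weaker inhibitor, a lower number a stronger inhibitor), compound 1 `C=CC(=O)Nc1cccc(NC(=O)CSc2nc(Nc3ccccc3Cl)c3ccccc3n2)c1` gives 20700 nM, compound 2 `C=CC(=O)Nc1cccc(NC(=O)CSc2nc(Nc3cccc(F)c3)c3ccccc3n2)c1` gives 6250 nM and compound 3 `C=CC(=O)Nc1cccc(NC(=O)CSc2nc(Nc3cccc(Cl)c3)c3ccccc3n2)c1` gives 7830 nM. Compound 3 therefore stands second highest of the three numbers: it sits within the scatter of compound 2, and it is separated from compound 1 by a 2.6-fold lower number from compound 1 to compound 3 (0.42 log units; beyond the scatter). Compound 4 `C=CC(=O)Nc1cccc(NC(=O)CSc2nc(Nc3cccc(OC)c3)c3ccccc3n2)c1` differs from compound 3 by methoxy in place of chloro on an aromatic carbon. Among the measured compounds shown here, the one measured step on an aromatic carbon of that ring is a 1.3-fold higher number from compound 2 to compound 3 (0.10 log units; within the scatter), an exchange of one halogen for another that stayed within the scatter; no measured step involves a methoxy group. Compound 4 is accordingly expected to show no step beyond the scatter in this assay, a 1.0-fold lower number from compound 3 to compound 4 (0.02 log units; within the scatter). The estimate for compound 4 is 7500 nM, with a range from 3000 nM to 18000 nM.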

Compound 4, half-maximal inhibitory concentration: 24200 nM
Compound 4: the middle estimate sits 3.2-fold (0.51 log units) below what was measured; the measured number lies above the stated range.
By their numbers in this assay, from the lowest: compounds 2 and 3 (each within the scatter of the next); then compounds 1 and 4 (each within the scatter of the next).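

In this assay, this aromatic carbon proved sensitive to the group it carries: the exchange of one halogen for another had stayed within the scatter, but methoxy in place of chloro gives a clear step (a 3.1-fold higher number from compound 3 to compound 4 (0.49 log units; beyond the scatter)), and methoxy in place of fluoro gives another (a 3.9-fold higher number from compound 2 to compound 4 (0.59 log units; beyond the scatter)). The 3-methoxyphenyl compound also falls within the scatter of the 2-chlorophenyl compound (a 1.2-fold higher number from compound 1 to compound 4 (0.07 log units; within the scatter)), so the advantage of the 3-halophenyl compounds does not extend to methoxy. No available evidence accounts for this result.

The compounds shown leave open whether a methyl, a hydroxyl or an amine on this carbon would group with the halogens or with methoxy.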